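This account rests on a few compounds, and the source may have more. Where it says the series, first, only, none or still open, it means among the compounds named here.

Measured compounds:
- compound 1 `CN(C)CCN(CCN(C)C)c1cccc(C(=O)N2CCc3ccc(OS(N)(=O)=O)cc3C2)c1` — 17.1% in an assay on HEK293 cells for inhibition of Steryl-sulfatase (Homo sapiens), tested at 1 uM; on this read-out higher numbers stand for a stronger effect at the one concentration tested and lower numbers for a weaker effect
- compound 2 `CCN(Cc1ccccn1)c1cccc(C(=O)N2CCc3ccc(OS(N)(=O)=O)cc3C2)c1` — 19.9%
- compound 3 `CCN(Cc1cccnc1)c1ccc(C(=O)N2CCc3ccc(OS(N)(=O)=O)cc3C2)cc1` — 85.2%

Compound 3 stands highest of the three numbers in this assay. Its nearest neighbour is compound 2, whose number lies well below it, beyond the scatter; compound 1 lies furthest below. Compound 2 and compound 3 differ in more than one place, so their two values show only the gap, not its source.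

Compound 4 `CCN(Cc1ccccc1)c1ccc(C(=O)N2CCc3ccc(OS(N)(=O)=O)cc3C2)cc1` is the next member to be measured. It differs from compound 3 by phenyl in place of pyridin-3-yl on a saturated chain carbon bound to a nitrogen on an aromatic ring.

Among the compounds with values here, the only measured single step, a number 2.8 percentage points higher from compound 1 to compound 2 (within the scatter), concerns a different position: there a large change of the amino group on the aromatic carbon left the number within the scatter. Within the data shown here, no measured step touches the saturated chain carbon bound to a nitrogen on an aromatic ring, so nothing directly bears on the swap of pyridin-3-yl for phenyl. The change removes one hydrogen-bond acceptor and otherwise keeps size and shape.

Given the weak sensitivity seen in the one step available, a small step is expected for compound 4, a number 10.2 percentage points lower from compound 3 to compound 4 (beyond the scatter), in the downward direction at most, likely within the scatter. The estimate for compound 4 is therefore 75%, with a range from 45% to 92%.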

Compound 4, a percentage reported as inhibition, at one concentration (the size of the read-out at that concentration, not a potency): 83.6%
For compound 4 the middle estimate is 8.6 percentage points below the measured one, within the range that was stated.
By their numbers in this assay, from the lowest: compounds 1 and 2 (each within the scatter of the next); then compounds 4 and 3 (each within the scatter of the next).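

In this assay, phenyl in place of pyridin-3-yl on a saturated chain carbon bound to a nitrogen on an aromatic ring comes with a number 1.6 percentage points lower from compound 3 to compound 4 (within the scatter). Within the data shown here, this is the only measured step at this place, and it shows that the read-out at the one concentration tested stays within the scatter when the ring nitrogen and the hydrogen-bond acceptor counted for pyridin-3-yl are exchanged for a ring of carbon only, so that acceptor is not needed to keep the number at this level. No measured data on the series offer an explanation for this result.

Going by these compounds, whether an aromatic ring is needed at this place at all remains open, as a cyclohexyl ring, a plain propyl chain or a phenyl ring carrying a carboxylic acid or an amine would test different changes from this one. On these data alone, the read-out gives the size of the effect at a single concentration rather than a potency, so any difference between the two compounds that this concentration does not resolve also remains open.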